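Exocyclic Alkene Swap with a Sulfur Ring on a Shared Core

A few compounds are considered here, and "the series" means these few. Any claim that something is new, unique, unknown or untested is made for them only; others in the source may bear on it.

Compound 1 `C/C(=C1/OC(=O)NC1=O)C(c1ccc(-c2ccc3cccc(F)c3c2)[nH]c1=O)C(C)C`: 17200 nM
Compound 2 `CCC(CC)C(/C=C1\OC(=O)NC1=O)c1ccc(-c2ccc3cccc(F)c3c2)[nH]c1=O`: 33700 nM
Compound 3 `CC(C)[C@@H](c1ccc(-c2ccc3cccc(F)c3c2)[nH]c1=O)[C@H]1OC(=O)NC1=O`: 31600 nM

In a physicochemical assay for solubility, in phosphate buffer, measured as kinetic solubility (on this read-out higher numbers stand for higher solubility and lower numbers for lower solubility), compound 1 gives 17200 nM, the lowest of the three numbers, yet its gaps to compound 3 and compound 2 both lie within the scatter, so no order among them can be drawn. Compound 4 `CC(C)C(/C=C1\SC(=O)NC1=O)c1ccc(-c2ccc3cccc(F)c3c2)[nH]c1=O` is not yet measured. It differs from compound 1 by a group of 8 heavy atoms (4 carbon, 1 nitrogen, 2 oxygen, 1 sulfur; one five-membered non-aromatic ring with 2 hetero atoms) in place of a group of 9 heavy atoms (5 carbon, 1 nitrogen, 3 oxygen; one five-membered non-aromatic ring with 2 hetero atoms), on a saturated chain carbon bound to an aromatic carbon and a saturated chain carbon. Within the data shown here, no measured pair shows such a change, so the step from compound 1 to compound 4 is uncertain; with an exchange of one ring heteroatom and the loss of a methyl, the shift in this assay is expected to stay within the scatter, a 1.2-fold higher number from compound 1 to compound 4 (0.07 log units; within the scatter). Compound 4 is therefore estimated at 20000 nM, with a range from 8000 nM to 50000 nM.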

Compound 4, solubility: 25600 nM
Compound 4: the middle estimate sits 1.3-fold (0.11 log units) below what was measured; measured number inside the range.
By their numbers in this assay, from the lowest: compounds 1, 4, 3 and 2 (each within the scatter of the next).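

Among these compounds, the step of a 1.5-fold higher number from compound 1 to compound 4 (0.17 log units; within the scatter) in this assay is the first that can be read at this saturated chain carbon. The group with a sulfur in its five-membered non-aromatic ring therefore stands in for the all-oxygen group without a change that can be told from the scatter. Nothing at hand accounts for the size of this step. Still open, from the compounds shown here alone, is how much of the step belongs to the sulfur and how much to the lost methyl, which change together here. Also open, going by these compounds, is how a carboxylic acid or an amine on this carbon would read in this assay.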